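The compounds below may be only part of what the source reports. "The series", "measured", "known", "first", "only" and "open" are said of these compounds alone.

Of the compounds shown here, three built on one shared core have been measured in a functional assay on CCRF-CEM cells (Homo sapiens) for antiproliferative activity, read by MTT assay, with a stated time of 24 h, tested at 12.5 uM; a lower number here means a stronger effect, a higher number a weaker effect of the compound at the concentration tested. Compound 3 `OC(CCn1nc2c(Br)c(Br)c(Br)c(Br)c2n1)c1ccccc1` gives 122%, the highest of the three numbers. Compound 1 `OC(CCn1nc2c(Br)c(Br)c(Br)c(Br)c2n1)c1cccc(Br)c1` gives 102%, and compound 2 `OC(CCn1nc2c(Br)c(Br)c(Br)c(Br)c2n1)c1ccc(F)cc1` gives 110%; between these two the step of a number 8 percentage points higher from compound 1 to compound 2 (within the scatter) stays within the scatter. The two steps up to compound 3 were both beyond the scatter: a number 20 percentage points higher from compound 1 to compound 3 (beyond the scatter) and a number 12 percentage points higher from compound 2 to compound 3 (beyond the scatter).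

Compound 4 `OC(CCn1nc2c(Br)c(Br)c(Br)c(Br)c2n1)c1ccc(Br)cc1` has not yet been measured. It differs from compound 3 in one place: bromo in place of hydrogen on an aromatic carbon. Cut one bond further out, phenyl becomes 4-bromophenyl. The measured steps that bear on this change are those in which a halogen left the same aromatic ring, a number 20 percentage points higher from compound 1 to compound 3 (beyond the scatter) and a number 12 percentage points higher from compound 2 to compound 3 (beyond the scatter); a halogen entering that ring would be expected to run the other way, by a comparable amount. A modest fall in this assay is therefore expected, a number 16 percentage points lower from compound 3 to compound 4 (beyond the scatter). Compound 4 is estimated at 106%, with a range from 92% to 120%.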

Compound 4, a percentage reported as activity, at one concentration (the size of the read-out at that concentration, not a potency): 101%
Estimate against measurement, compound 4: 5 percentage points above; the measured number falls inside the stated range.
By their numbers in this assay, from the lowest: compounds 4, 1 and 2 (each within the scatter of the next); then compound 3.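

Bromo in place of hydrogen, on the six-membered aromatic ring and para to a large group, gives a direct step in this assay: a number 21 percentage points lower from compound 3 to compound 4 (beyond the scatter). Exchanging the halogen at that place gives a number 9 percentage points lower from compound 2 to compound 4 (within the scatter), and 4-bromophenyl in place of 3-bromophenyl gives a number 1 percentage points lower from compound 1 to compound 4 (within the scatter), both within the scatter, so among these four compounds the clear divide lies between the three with a halogen on the ring and compound 3, which has none. Nothing measured here explains why a halogen on this ring lowers the number.

On these data alone, it remains open whether a methoxy group or an amine at the same ring place would lower the number as bromo does. Also open, as far as these compounds go, is how a longer chain linking the shared core to the hydroxyl-bearing carbon would read.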